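Chain-terminal pyridyl swap in a phenolic ketone series

The source may report more compounds than this note shows. Statements on the series, on what has been measured and on what is new or still open speak of the compounds shown alone.

Measured so far:
compound 1 `Cc1c(OCCCCOc2cccnc2)ccc(C(=O)CC(C)C)c1O`, 1720 nM
compound 2 `CC(C)CC(=O)c1ccc(OCCCCOc2cccnc2)c(Br)c1O`, 575 nM

In a functional assay for binding affinity to metabotropic glutamate receptor 2 (Homo sapiens), read by GTPgammaS binding (a higher number here means that more compound is needed for the effect, a lower number that less compound is needed), compound 1 gives 1720 nM, the highest of the two numbers; the nearest is compound 2 with 575 nM, and the step of a 3.0-fold lower number from compound 1 to compound 2 (0.48 log units; beyond the scatter) is the only one in hand.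

Compound 3 `Cc1c(OCCCCSc2ccncc2)ccc(C(=O)CC(C)C)c1O` has not been measured. It differs from compound 1 by (pyridin-4-yl)sulfanyl in place of (pyridin-3-yl)oxy on a saturated chain carbon, four bonds along the chain from an oxygen on an aromatic ring. Among the measured compounds shown here, the one measured step concerns a substituent on the aromatic ring, not the chain end, so it does not bear on this change; no step in the data touches the pyridyl or the linking atom. For this assay the direction is therefore open, and a step of the size seen from compound 1 to compound 2 in either direction cannot be excluded. Compound 3 is expected near compound 1, about 2000 nM, in the range 600 nM to 7000 nM, which means an estimated 1.2-fold higher number from compound 1 to compound 3 (0.07 log units; within the scatter).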

Compound 3, half-maximal effective concentration: 340 nM
Beside the measured number, compound 3's estimate is 5.9-fold (0.77 log units) above it; the measured number lies below the stated range.
By their numbers in this assay, from the lowest: compounds 3 and 2 (each within the scatter of the next); then compound 1.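

In this assay the chain end proves to be a responsive position, with a 5.1-fold lower number from compound 1 to compound 3 (0.70 log units; beyond the scatter) on moving to (pyridin-4-yl)sulfanyl from (pyridin-3-yl)oxy. Among the compounds shown here, the earlier step on the aromatic ring, a 3.0-fold lower number from compound 1 to compound 2 (0.48 log units; beyond the scatter), showed only that the ring substituent moves the number, so this is the first sign that the far end of the chain matters too. The change alters the linking atom and the pyridyl attachment point together, and nothing measured here explains the shift.

On these data alone, it remains open which of the two alterations carries the step, a question that (pyridin-3-yl)sulfanyl and (pyridin-4-yl)oxy at the same place would address. Also open, as far as these compounds go, are whether bromo on the aromatic ring combines with the new chain end, and how an amine, a carboxylic acid or a longer chain would read at this position.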